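Iodo for Bromo on the Fused Ring

This account rests on a few compounds, and the source may have more. Where it says the series, first, only, none or still open, it means among the compounds named here.

Compound 3 `CC[C@H](C)[C@H](Nc1nc(-c2ccccc2)nc2ccc(Br)cc12)C(=O)O` gives 0% in a functional assay on the whole organism (strain Wistar) for inhibition, with Rattus norvegicus as the target, read by paw edema, at a dose of 100 mg/kg by the oral route; on this read-out lower numbers stand for less inhibition and higher numbers for more inhibition at the one dose given (going by the name of the read-out). That places it level with compound 1 `O=C(O)CNc1nc(-c2ccccc2)nc2ccc(I)cc12`, which gives 0%, the two together the lowest of the three numbers; compound 2 `CC[C@H](C)[C@H](Nc1nc(-c2ccccc2)nc2ccccc12)C(=O)O` gives 4.1%, and the step of a number 4.1 percentage points lower from compound 2 to compound 3 (within the scatter) lies within the scatter. Compound 4 `CC[C@H](C)[C@H](Nc1nc(-c2ccccc2)nc2ccc(I)cc12)C(=O)O` differs from compound 3 by iodo in place of bromo on an aromatic carbon. No measured step covers this exchange directly; compound 1 carries the iodo group and compound 3 the bromo group, and their values show no change at the digits shown, while the only measured step, a number 4.1 percentage points lower from compound 2 to compound 3 (within the scatter), was itself within the scatter. The step of no change at the digits printed from compound 3 to compound 4 (within the scatter) is therefore expected to stay within the scatter. Compound 4 is estimated at 0%, with a range from 0% to 8%.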

Compound 4, a percentage reported as inhibition, in the whole organism at one dose (the size of the read-out at that dose, not a potency): 0%
The estimate for compound 4 equals the measured number at the digits printed, and the stated range covers the measured number.
By their numbers in this assay, from the lowest: compounds 1, 3, 4 and 2 (each within the scatter of the next).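

In this assay the exchange of bromo for iodo on the aromatic carbon now reads directly as no change at the digits printed from compound 3 to compound 4 (within the scatter), so this position has a measured halogen swap. Iodo in place of hydrogen reads as a number 4.1 percentage points lower from compound 2 to compound 4 (within the scatter), and the chain change, sec-butyl in place of hydrogen, can now be read in one place as no change at the digits printed from compound 1 to compound 4 (within the scatter), so neither change separates these compounds. Among these compounds, no evidence on these compounds bears on the result.

As far as these compounds go, whether an amine or a methoxy group on that aromatic carbon would move the number beyond the scatter stays open. So does the effect of a longer chain in place of sec-butyl.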